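A few compounds are considered here, and "the series" means these few. Any claim that something is new, unique, unknown or untested is made for them only; others in the source may bear on it.

In a functional assay on HCT-116 cells (Homo sapiens) for cytotoxicity, read by MTT assay, with a stated time of 72 h (on this read-out lower numbers stand for stronger inhibition and higher numbers for weaker inhibition), compound 1 `CCC[S+]([O-])CCCCN=C=S` gives 3950 nM within a small set of close relatives. Compound 2 `COc1ccc(C[S+]([O-])CCCCN=C=S)cc1` gives 5460 nM and compound 3 `[O-][S+](CCCCN=C=S)Cc1ccccn1` gives 3720 nM there as well. Both of these numbers lie within the usual scatter of the number for compound 1, so no ranking can be read from them.

Compound 4 `[O-][S+](CCCCN=C=S)Cc1ccco1` has not yet been measured. It carries furan-2-yl in place of ethyl on a saturated chain carbon bound to a sulfur, a change counted as furan-2-yl in place of ethyl on a saturated chain carbon bound to a sulfur against compound 1.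

Compound 2 at 5460 nM and compound 3 at 3720 nM also carry a ring at that place and stay within the scatter of compound 1, so no step beyond the scatter is expected in either direction in this assay for this change. The estimated step of a 1.0-fold higher number from compound 1 to compound 4 (0.01 log units; within the scatter) is therefore expected to be small. For compound 4 the estimated value is 4000 nM with an expected range from 2200 nM to 7500 nM on repeated measurement.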

Compound 4, half-maximal inhibitory concentration: 3470 nM
Compound 4: the middle estimate sits 1.2-fold (0.06 log units) above what was measured; measured number inside the range.
By their numbers in this assay, from the lowest: compounds 4, 3, 1 and 2 (each within the scatter of the next).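

In this assay, exchanging ethyl for furan-2-yl gives a 1.1-fold lower number from compound 1 to compound 4 (0.06 log units; within the scatter), so no real difference can be claimed between the two compounds. This adds a five-membered aromatic ring with 1 hetero atom and a hydrogen-bond acceptor to the groups tried at this place, and even this larger group, compared with ethyl, brings no step beyond the scatter. No measurement here explains why the read-out is so insensitive to this change.

The compounds shown leave open whether any group at this place can shift the number beyond the scatter, for instance an amine, a carboxylic acid or a longer chain. They also leave open whether the same tolerance would appear on cells other than the one line tested here.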